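A few compounds are considered here, and "the series" means these few. Any claim that something is new, unique, unknown or untested is made for them only; others in the source may bear on it.

Measured compounds:
- compound 1, `COc1ccc(F)c([C@H]2CC[C@H](COc3cccc([C@@H](CC(=O)O)C4CC4)c3)CC2)c1`: 199 nM in a functional assay on cells for agonist activity at Free fatty acid receptor 1 (Homo sapiens), read by HTRF and inositol phosphate accumulation, with a stated time of 90 min; a lower number here means that less compound is needed, a higher number that more compound is needed for the effect
- compound 2, `COc1ccc(F)c([C@H]2CC[C@H](COc3cccc([C@H](C4CC4)[C@@](C)(F)C(=O)O)c3)CC2)c1`: 3.1 nM in this assay

For the measured compounds named here, compound 2 stands at the low end of the pair; the only comparison at hand is a 64-fold lower number from compound 1 to compound 2 (1.81 log units; beyond the scatter), a large step beyond the scatter. That step, however, changes the carboxymethyl to 1-carboxy-1-fluoroethyl at once, so the share carried by the fluorine and the share carried by the added methyl cannot be separated.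

Compound 3, `COc1ccc(F)c([C@H]2CC[C@H](COc3cccc([C@H](C4CC4)C(C)(C)C(=O)O)c3)CC2)c1`, differs from compound 2 by 1-carboxy-1-methylethyl in place of 1-carboxy-1-fluoroethyl on a saturated chain carbon bound to an aromatic carbon and a saturated ring carbon. Going by the values given here, no measured pair shows a fluorine-to-methyl exchange alone, so the step from compound 2 to compound 3 in this assay has to be read from the single measured step as an upper bound on what is at risk: most of the gain over compound 1 may survive, part of it may not.

Compound 3 is expected to give 8 nM in this assay, within 2.5 nM to 35 nM, i.e. an expected step of a 2.6-fold higher number from compound 2 to compound 3 (0.41 log units; beyond the scatter).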

Compound 3, half-maximal effective concentration: 220 nM
Compound 3: middle estimate off by 28-fold (1.44 log units), on the low side; measured number above the stated range.
By their numbers in this assay, from the lowest: compound 2; then compounds 1 and 3 (each within the scatter of the next).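

In this assay, 1-carboxy-1-methylethyl in place of 1-carboxy-1-fluoroethyl gives a 71-fold higher number from compound 2 to compound 3 (1.85 log units; beyond the scatter) and so removes the large gain seen with compound 2. On this saturated chain carbon, carboxymethyl and 1-carboxy-1-methylethyl are not separated by a 1.1-fold higher number from compound 1 to compound 3 (0.04 log units; within the scatter), which lies within the scatter; the gain therefore depends on the fluorine-bearing group and does not follow from a fully substituted carbon alone. Nothing at hand bears on the cause of this sensitivity.

Still open, as far as these compounds go, is whether fluorine is sufficient without the methyl, as carboxyfluoromethyl or carboxydifluoromethyl would show, or whether the methyl and fluorine work only together. Also open, from the compounds shown here alone, are the effect of a hydroxyl or chlorine in place of the fluorine and the effect of the opposite configuration at the fluorine-bearing stereocentre.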